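A few compounds are considered here, and "the series" means these few. Any claim that something is new, unique, unknown or untested is made for them only; others in the source may bear on it.

Three compounds share one core and differ only in the fluorophenyl group on the amide-type nitrogen: compound 1 `COc1cc(-c2cc(C(=O)O)c3ccccc3n2)ccc1OCC(=O)Nc1ccccc1F`, compound 2 `COc1cc(-c2cc(C(=O)O)c3ccccc3n2)ccc1OCC(=O)Nc1cccc(F)c1` and compound 3 `COc1cc(-c2cc(C(=O)O)c3ccccc3n2)ccc1OCC(=O)Nc1ccc(F)cc1`. In a physicochemical assay for lipophilicity, using the shake flask method, in phosphate buffer, measured as octanol-water partition, at pH 7.4 (on this read-out lower numbers stand for lower lipophilicity and higher numbers for higher lipophilicity), compound 1 gives 0.9, compound 2 gives 1.6 and compound 3 gives 1.1, so compound 2 stands highest of the three. The measured steps read a number 0.70 log units higher from compound 1 to compound 2 (beyond the scatter) and a number 0.50 log units lower from compound 2 to compound 3 (beyond the scatter), while a number 0.20 log units higher from compound 1 to compound 3 (within the scatter). Compound 4 `COc1cc(-c2cc(C(=O)O)c3ccccc3n2)ccc1OCC(=O)Nc1ccccc1C(F)(F)F` carries 2-(trifluoromethyl)phenyl in place of 3-fluorophenyl on an amide-type nitrogen. For the measured compounds named here, no measured step brings in a trifluoromethyl group; the steps seen so far only shift the place of one fluorine, so they bear on this change loosely. Compound 4 is expected to give 1.7, within 1 to 2.4. That estimate means a number 0.10 log units higher from compound 2 to compound 4 (within the scatter).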

Compound 4, distribution coefficient: 1.3
Estimate against measurement, compound 4: 0.40 log units above, and the stated range covers the measured number.
By their numbers in this assay, from the lowest: compounds 1, 3, 4 and 2 (each within the scatter of the next, the first and the last beyond it).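

In this assay the number at this position moves when the group itself changes, not only when a fluorine changes place: trifluoromethyl in place of fluoro on an aromatic carbon gives a number 0.40 log units higher from compound 1 to compound 4 (beyond the scatter) as its step. Against the 3-fluorophenyl and 4-fluorophenyl groups, 2-(trifluoromethyl)phenyl shows no clear shift, with a number 0.30 log units lower from compound 2 to compound 4 (within the scatter) and a number 0.20 log units higher from compound 3 to compound 4 (within the scatter) as its steps. On these data alone, how a nitrile or an amine on this phenyl ring would read remains open. No evidence at hand speaks to why the numbers fall as they do.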